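Lengthening the isothiocyanate chain on the anilide arm

A few compounds are considered here, and "the series" means these few. Any claim that something is new, unique, unknown or untested is made for them only; others in the source may bear on it.

Of the compounds shown here, three sharing one core have been measured in a functional assay on NCI-H1299 cells (Homo sapiens) for inhibition, read by CCK-8 assay, with a stated time of 72 h, tested at 1 uM; on this read-out lower numbers stand for a weaker effect and higher numbers for a stronger effect at the one concentration tested. Compound 1 `CN(C)C(=O)c1cc2cnc(Nc3ccc(C(=O)NCCCCN=C=S)cc3)nc2n1C1CCCC1` gives 55.2%. For the measured compounds named here, compound 2 `CN(C)C(=O)c1cc2cnc(Nc3ccc(C(=O)NCCCCCN=C=S)cc3)nc2n1C1CCCC1` gives 50.3%; the step of a number 4.9 percentage points lower from compound 1 to compound 2 (within the scatter) is the only chain-lengthening comparison among the measured compounds, and it stays within the scatter. Compound 3 `CN(C)C(=O)c1cc2cnc(Nc3ccc(NC(=O)CCCCCN=C=S)cc3)nc2n1C1CCCC1` gives 34.3%, the lowest of the three numbers: the steps of a number 20.9 percentage points lower from compound 1 to compound 3 (beyond the scatter) and a number 16 percentage points lower from compound 2 to compound 3 (beyond the scatter) both fall beyond the scatter, so compound 3 stands apart from the other two, with compound 2 the nearer and compound 1 the further of them.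

Compound 4 `CN(C)C(=O)c1cc2cnc(Nc3ccc(NC(=O)CCCCCCN=C=S)cc3)nc2n1C1CCCC1` has not yet been measured. It differs from compound 3 by a group of 4 heavy atoms (2 carbon, 1 nitrogen, 1 sulfur; no ring) in place of a group of 3 heavy atoms (1 carbon, 1 nitrogen, 1 sulfur; no ring), on a saturated chain carbon, five bonds along the chain from a carbonyl carbon. Going by the values given here, the one measured step of the same kind, a number 4.9 percentage points lower from compound 1 to compound 2 (within the scatter), added one saturated chain carbon before the isothiocyanate and changed the read-out by no more than the scatter. The author therefore expects the step of a number 2.3 percentage points lower from compound 3 to compound 4 (within the scatter) to lie within the scatter as well, with no direction he would trust. On that basis compound 4 is estimated to give 32% in this assay, with a range from 18% to 46%.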

Compound 4, a percentage reported as inhibition, at one concentration (the size of the read-out at that concentration, not a potency): 50.9%
Compound 4: the middle estimate sits 18.9 percentage points below what was measured; the whole stated range lies below it.
By their numbers in this assay, from the lowest: compound 3; then compounds 2, 4 and 1 (each within the scatter of the next).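

In this assay, the added saturated chain carbon, five bonds along the chain from a carbonyl carbon, proves able to move the read-out on the arm of compound 3, with a number 16.6 percentage points higher from compound 3 to compound 4 (beyond the scatter). The earlier chain-lengthening comparison gave no sign of this, and the effect of the same change does not carry over from one arm to the other: the same change on two cores in this assay, a number 4.9 percentage points lower (within the scatter) from compound 1 to compound 2 and a number 16.6 percentage points higher (beyond the scatter) from compound 3 to compound 4, 21.5 percentage points apart, beyond the scatter of two such steps With the longer chain, compound 4 no longer stands apart from the compounds carrying the other arm, as the steps of a number 0.6 percentage points higher from compound 2 to compound 4 (within the scatter) and a number 4.3 percentage points lower from compound 1 to compound 4 (within the scatter) show, so the separation seen earlier belongs to compound 3 with its shorter chain and not to its arm as such.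

A single added carbon on each arm cannot show whether the read-out would keep rising, level off or fall with a still longer chain, or what a shorter chain would do on the arm of compound 3. From the compounds shown here alone, what an amine or a carboxylic acid in place of the isothiocyanate would give also remains open, and these single-concentration numbers give no potency for any of the four compounds.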